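From trifluoromethyl to fluoro on compound 3

The source may report more compounds than this note shows. Statements on the series, on what has been measured and on what is new or still open speak of the compounds shown alone.

Three related compounds have been measured in a functional assay on HCT-116 cells (Homo sapiens) for inhibition, read by MTT assay, with a stated time of 72 h; a lower number here means a stronger inhibitor, a higher number a weaker inhibitor. Compound 1 `Nc1ccccc1NC(=O)c1ccc(CNCc2nc(-c3ccc(C(F)(F)F)cc3)no2)cc1` gives 19700 nM, compound 2 `Nc1ccccc1NC(=O)c1ccc(CNCc2nc(-c3ccc(Cl)cc3)no2)cc1` gives 6810 nM, and compound 3 `O=C(NO)c1ccc(CNCc2nc(-c3ccc(C(F)(F)F)cc3)no2)cc1` gives 43100 nM, the highest number of the three and so the weakest inhibitor among them. Compound 4 `O=C(NO)c1ccc(CNCc2nc(-c3ccc(F)cc3)no2)cc1` differs from compound 3 by one change, fluoro in place of trifluoromethyl on an aromatic carbon. The nearest guide is a 2.9-fold lower number from compound 1 to compound 2 (0.46 log units; beyond the scatter), a modest step seen with chloro in place of trifluoromethyl. It is only a rough guide, since chloro is not fluoro and neither compound in that pair shares the hydroxy group of compound 3. That other change, hydroxy in place of 2-aminophenyl, gave a 2.2-fold higher number from compound 1 to compound 3 (0.34 log units; beyond the scatter), also modest, so the two ends of these molecules are not independent of each other in any known way. A modest fall in this assay is therefore expected, an estimated 2.4-fold lower number from compound 3 to compound 4 (0.38 log units; beyond the scatter). Compound 4 is estimated at 18000 nM, with an expected range of 7000 nM to 45000 nM.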

Compound 4, half-maximal inhibitory concentration: 17800 nM
For compound 4 the middle estimate is 1.0-fold (0.00 log units) above the measured one; low and high end bracket the measured number.
By their numbers in this assay, from the lowest: compound 2; then compounds 4 and 1 (each within the scatter of the next); then compound 3.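

In this assay fluoro in place of trifluoromethyl gives a 2.4-fold lower number from compound 3 to compound 4 (0.38 log units; beyond the scatter) and so shows that a halogen at this place can lower the number with hydroxy on the amide-type nitrogen, not only with 2-aminophenyl there. The earlier result of a 2.9-fold lower number from compound 1 to compound 2 (0.46 log units; beyond the scatter) came with chloro and 2-aminophenyl, so two modest falls now point the same way across these two pairs. Nothing measured here says why the number falls with this change.

Chloro and fluoro appear here only with different groups on the amide-type nitrogen, so whether the choice of halogen matters stays open. These compounds also do not tell what an amine, a methoxy group or a carboxylic acid on this aromatic carbon would do to the number.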